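The source may hold more compounds than are shown below. What is called first, only, known or untested is meant among the compounds shown, and "the series" means these compounds.

Working notes, series overview. For the measured compounds named here, compound 2 `COc1cccc(Sc2c(NS(=O)(=O)c3ccc(C(C)(C)C)cc3)noc2C)c1` gives 530 nM in an assay on A7R5 cells for displacement of a labelled ligand from Endothelin-1 receptor (Rattus norvegicus) (a higher number here means a weaker inhibitor, a lower number a stronger inhibitor), and holds the lowest of the two numbers so far; its nearest neighbour is compound 1 `COc1cccc(Sc2c(NS(=O)(=O)c3ccc(C(C)(C)C)cc3)noc2CCCC#N)c1`, which in this assay gives 1300 nM. Going by the values given here, the one measured step, a 2.5-fold lower number from compound 1 to compound 2 (0.39 log units; beyond the scatter), is modest but beyond the scatter. Compound 3 `COc1cccc(Sc2c(NS(=O)(=O)c3ccc(C(C)(C)C)cc3)noc2CCCC(C)=O)c1` differs from compound 2 by 2-acetylethyl in place of hydrogen on a saturated chain carbon bound to an aromatic carbon. That step most resembles the reverse of the step from compound 1 to compound 2, both extending the same chain from hydrogen to a polar-terminated chain, so a weakening of similar size is expected, as a 2.1-fold higher number from compound 2 to compound 3 (0.32 log units; beyond the scatter). Compound 3 is therefore estimated at 1100 nM, range 400 nM to 3000 nM.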

Compound 3, half-maximal inhibitory concentration: 1300 nM
Beside the measured number, compound 3's estimate is 1.2-fold (0.07 log units) below it; low and high end bracket the measured number.
By their numbers in this assay, from the lowest: compound 2; then compounds 1 and 3 (each within the scatter of the next).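

In this assay, 2-acetylethyl in place of hydrogen gives a 2.5-fold higher number from compound 2 to compound 3 (0.39 log units; beyond the scatter), a step of the same size as that between hydrogen and the nitrile-ended chain. Acetyl in place of cyano at the chain end gives no change at the digits printed from compound 1 to compound 3 (within the scatter), so these two end groups are not told apart at this position. Both chains therefore read alike here, whichever of the two ends they carry.

Open, going by these compounds, is whether an amine or a carboxylic acid at the chain end would depart from this reading. Also open, on these data alone, is whether the plain chain without an end group, or a longer chain, accounts for the step from hydrogen. Nothing at hand explains these numbers.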